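Norvaline benzylamides: racemate versus drawn R enantiomer

A few compounds are considered here, and "the series" means these few. Any claim that something is new, unique, unknown or untested is made for them only; others in the source may bear on it.

Compound 1 `CSCC[C@@H](N)C(=O)NCc1ccccc1` — 75 mg/kg
Compound 2 `CCC[C@@H](N)C(=O)NCc1ccccc1` — 21 mg/kg

In a functional assay on the whole organism (strain NMRI) with Mus musculus as the target, in the maximal electroshock model, with a stated time of 30 min (a lower number here means that less compound is needed, a higher number that more compound is needed for the effect), compound 2 holds the lowest of the two numbers, with compound 1 the nearest, a 3.6-fold lower number from compound 1 to compound 2 (0.55 log units; beyond the scatter) step apart. Compound 3 `CCCC(N)C(=O)NCc1ccccc1` differs from compound 2 only in this: the two compounds have the same atoms and bonds; at least one stereo element is drawn with a configuration in one of them and without one in the other: 1 of 1 stereo elements differ; a stereocentre at a saturated chain carbon is drawn R in compound 2 and without a configuration in compound 3. Going by the values given here, no measured step touches a stereo element; the one step known concerns a substituent, so it does not guide this change. Loss of a single drawn configuration is expected to give a step of a 1.4-fold higher number from compound 2 to compound 3 (0.15 log units; within the scatter) or none beyond the scatter. Compound 3 is therefore estimated at 30 mg/kg, range 17 mg/kg to 60 mg/kg.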

Compound 3, dose for half-maximal effect: 39 mg/kg
The estimate for compound 3 lay 1.3-fold (0.11 log units) below the measured number; measured number inside the range.
By their numbers in this assay, from the lowest: compounds 2, 3 and 1 (each within the scatter of the next, the first and the last beyond it).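

In this assay, the stereocentre at the saturated chain carbon gives the first read on stereochemistry in this series: a 1.9-fold higher number from compound 2 to compound 3 (0.27 log units; within the scatter), whereas the substituent step between compounds 1 and 2 lay beyond the scatter. Compounds 2 and 3 cannot be told apart here, and the only difference between them is this: the fact that one of compounds 2 and 3 is drawn with a defined configuration and the other without, at the place where they differ

The compound drawn with the opposite configuration at this carbon is not among those shown, so the gap between the two configurations stays open. Also open, going by these compounds, is how a longer chain or a methoxy group in place of the methyl would read.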